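Sulfonate ester series: pivalamide to cyclopropyl carbamoyl

The compounds below may be only part of what the source reports. "The series", "measured", "known", "first", "only" and "open" are said of these compounds alone.

Measured so far in a functional assay on M21 cells (Homo sapiens) for antiproliferative activity, read by sulforhodamine B assay, with a stated time of 48 h; a lower number here means a stronger inhibitor, a higher number a weaker inhibitor:
Compound 1 `CC(C)C(=O)Nc1cccc(S(=O)(=O)Oc2ccccc2C(C)C)c1` gives 17000 nM.
Compound 2 `CC(C)c1ccccc1OS(=O)(=O)c1ccc(NC(=O)C(C)(C)C)cc1` gives 6200 nM.
Compound 3 `CC(C)(C)C(=O)Nc1ccc(S(=O)(=O)Oc2ccccc2I)cc1` gives 8300 nM.

Compound 3 sits second highest of the three numbers in this assay. For the measured compounds named here, compound 2 is its nearest neighbour, and the one measured single-point step, a 1.3-fold higher number from compound 2 to compound 3 (0.13 log units; within the scatter), lies within the scatter. Going by the values given here, compound 1 shows the highest number of the three and stands beyond the scatter from compound 3; no single-point step links them.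

Compound 4 `O=C(Nc1ccc(S(=O)(=O)Oc2ccccc2I)cc1)NC1CC1` differs from compound 3 in one place: cyclopropylamino in place of tert-butyl on a carbonyl carbon. Among the compounds with values here, the only measured step concerns an aromatic substituent, iodo in place of isopropyl, and says nothing about exchanging the group on the carbonyl carbon. The measured steps therefore give no guidance on the size or direction of this change; the three numbers span a narrow band, so the working assumption is a step of no clear direction in this assay, with a wide range to cover both outcomes.

Compound 4 is accordingly expected near 8000 nM, between 2500 nM and 25000 nM. The step this implies, a 1.0-fold lower number from compound 3 to compound 4 (0.02 log units; within the scatter), is an expectation only, not a measurement.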

Compound 4, half-maximal inhibitory concentration: 11000 nM
Beside the measured number, compound 4's estimate is 1.4-fold (0.14 log units) below it; the measured number falls inside the stated range.
By their numbers in this assay, from the lowest: compounds 2, 3, 4 and 1 (each within the scatter of the next, the first and the last beyond it).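

In this assay, for the compounds shown here, cyclopropylamino in place of tert-butyl on a carbonyl carbon gives a 1.3-fold higher number from compound 3 to compound 4 (0.12 log units; within the scatter), so the first measured exchange at this position leaves compound 3 and compound 4 indistinguishable in this read-out. The earlier step covered only an aromatic substituent, whereas this one shows that (tert-butyl)carbonyl and cyclopropylcarbamoyl can be exchanged on the amide-type nitrogen with no separation beyond the scatter, even though the entering group brings a three-membered ring and a hydrogen-bond donor absent from the group that leaves. No supporting data accompany this result to explain it.

Still open, on these data alone, is whether a different group on this carbonyl carbon, such as a longer alkyl chain, a morpholine or a carboxylic acid, would give a step beyond the scatter in this assay. Also open, as far as these compounds go, is whether the same exchange would read alike with isopropyl in place of iodo on the aromatic carbon, and a single step cannot show whether this position matters at all for the series.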